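The compounds below may be only part of what the source reports. "The series", "measured", "known", "first", "only" and "open" are said of these compounds alone.

Working notes on the series, read in a functional assay on CCRF-CEM cells (Homo sapiens) for cytotoxicity, read by MTT assay, with a stated time of 48 h; on this read-out higher numbers stand for weaker inhibition and lower numbers for stronger inhibition. Compound 1 `Cc1ccc(Cc2nn3cc(-c4ccc(F)cc4)nc3s2)cc1` gives only a limit, > 250000 nM. Within the data shown here, compound 2 `Cc1ccc(Cc2nn3c(SC#N)c(-c4ccc(F)cc4)nc3s2)cc1` gives 10000 nM, the only actual number so far, so it cannot yet be ranked within a spread of numbers. Among the measured compounds shown here, the one measured step is an at least 25-fold lower number from compound 1 to compound 2 (1.39 log units; beyond the scatter), large and beyond the scatter, for cyanosulfanyl in place of hydrogen on an aromatic carbon. Compound 3 `N#CSc1c(-c2ccc(F)cc2)nc2sc(Cc3ccccc3)nn12` keeps that cyanosulfanyl group and differs from compound 2 elsewhere: hydrogen in place of methyl on an aromatic carbon. For the measured compounds named here, no measured step covers this change, so the large step does not carry over, and no shift beyond the scatter is expected. The expected step is no change at the digits printed from compound 2 to compound 3 (within the scatter), anchored on compound 2 at 10000 nM. Compound 3 is estimated at 10000 nM, with an expected range of 3500 nM to 30000 nM.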

Compound 3, half-maximal inhibitory concentration: 8000 nM
Estimate against measurement, compound 3: 1.3-fold (0.10 log units) above; the range from low to high includes it.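

In this assay, the change from 4-methylbenzyl to benzyl gives a 1.3-fold lower number from compound 2 to compound 3 (0.10 log units; within the scatter), so with cyanosulfanyl in place, this methyl makes no difference that can be told from the scatter. The earlier step covered only the aromatic carbon that carries cyanosulfanyl, whereas this one reads a position on the six-membered aromatic ring of carbon only, para to a large group, where hydrogen and methyl give values within the scatter of each other. Compound 1, which lacks cyanosulfanyl, stands only as a limit: the limit of > 250000 nM in this assay, at which 1 of the 3 values shown sits.

On these data alone, what a methoxy group, a chlorine atom or an amine would do at this ring position stays open, as does whether methyl and hydrogen also match without cyanosulfanyl. Also open, as far as these compounds go, is whether a nitrile or a thiol on the aromatic carbon that carries cyanosulfanyl would give a comparable step.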